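Nitro-Bearing Ring Replaces Fluorine and Methoxy on the Chain

The source may report more compounds than this note shows. Statements on the series, on what has been measured and on what is new or still open speak of the compounds shown alone.

Of the compounds shown here, three sharing one core have been measured. Compound 1 `COc1ccc(C(=O)c2cc(OC)c(OC)c(OC)c2)cc1NC(=O)/C=C/c1cc(OC)c(OC)c(OC)c1` gives 6300 nM in a functional assay on DU-145 cells (Homo sapiens) for cytotoxicity, read by MTT assay, with a stated time of 72 h; a lower number here means a stronger inhibitor, a higher number a weaker inhibitor. Compound 2 `COc1ccc(C(=O)c2cc(OC)c(OC)c(OC)c2)cc1NC(=O)/C=C/c1ccc(F)cc1` gives 3900 nM, and compound 3 `COc1cc(/C=C/C(=O)Nc2cc(C(=O)c3cc(OC)c(OC)c(OC)c3)ccc2OC)ccc1F` gives 12100 nM, so compound 3 holds the highest number of the three, though its gap to compound 1 is within the scatter. Compound 4 `COc1ccc(C(=O)c2cc(OC)c(OC)c(OC)c2)cc1NC(=O)/C=C/c1ccc([N+](=O)[O-])cc1` is the next step: 4-nitrophenyl in place of 4-fluoro-3-methoxyphenyl on a double-bonded chain carbon bound to a double-bonded chain carbon. Among the measured compounds shown here, no measured step introduces a nitro group. The related steps are a 3.1-fold higher number from compound 2 to compound 3 (0.49 log units; beyond the scatter) and a 1.9-fold higher number from compound 1 to compound 3 (0.28 log units; within the scatter), so removing the methoxy, as happens here, points toward a lower number, while nothing shows what nitro does in place of fluorine. For compound 4 a modest fall is therefore expected, a 2.7-fold lower number from compound 3 to compound 4 (0.43 log units; beyond the scatter). Compound 4 is estimated at 4500 nM, within 1500 nM to 13000 nM.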

Compound 4, half-maximal inhibitory concentration: 15600 nM
Beside the measured number, compound 4's estimate is 3.5-fold (0.54 log units) below it; the whole stated range lies below it.
By their numbers in this assay, from the lowest: compounds 2, 1, 3 and 4 (each within the scatter of the next, the first and the last beyond it).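

In this assay, among the compounds shown here, nitro in place of fluoro on an aromatic carbon gives a 4.0-fold higher number from compound 2 to compound 4 (0.60 log units; beyond the scatter), the first measured look at a nitro group here. Replacing the 3,4,5-trimethoxyphenyl gives a 2.5-fold higher number from compound 1 to compound 4 (0.39 log units; beyond the scatter), whereas a 1.3-fold higher number from compound 3 to compound 4 (0.11 log units; within the scatter) leaves 4-nitrophenyl and 4-fluoro-3-methoxyphenyl not told apart. No evidence at hand accounts for these steps.

From the compounds shown here alone, how an amine or a carboxylic acid would read in place of the nitro remains open. So does whether adding a methoxy to the 4-nitrophenyl would shift the number.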